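Thiazolidinedione series: ethoxy to methoxy on the aryl ether

This account rests on a few compounds, and the source may have more. Where it says the series, first, only, none or still open, it means among the compounds named here.

Measured compounds:
- compound 1 `CC(C)=CCOc1c(C)c(C)c2c(c1C)CCC(C)(COc1ccc(/C=C3\SC(=O)NC3=O)cc1F)O2`: 87%
- compound 2 `CC(C)=CCOc1c(C)c(C)c2c(c1C)CCC(C)(COc1ccc(/C=C3\SC(=O)NC3=O)cc1C)O2`: 56%
- compound 3 `CCOc1cc(/C=C2\SC(=O)NC2=O)ccc1OCC1(C)CCc2c(C)c(OCC=C(C)C)c(C)c(C)c2O1`: 84%

In a functional assay on MCF7 cells (Homo sapiens), tested at 5 uM (on this read-out higher numbers stand for a weaker effect at the one concentration tested and lower numbers for a stronger effect), compound 3 stands second highest of the three numbers. Its nearest neighbour is compound 1, differing by a number 3 percentage points lower from compound 1 to compound 3 (within the scatter), a gap that says nothing about order. Its furthest is compound 2, from which it is separated by a number 28 percentage points higher from compound 2 to compound 3 (beyond the scatter).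

Compound 4 `COc1cc(/C=C2\SC(=O)NC2=O)ccc1OCC1(C)CCc2c(C)c(OCC=C(C)C)c(C)c(C)c2O1` is not yet measured. It differs from compound 3 by hydrogen in place of methyl on a saturated chain carbon bound to an oxygen on an aromatic ring.

Among the measured compounds shown here, no measured step changes the ethoxy group at this carbon; the two steps that touch the same aromatic carbon exchange ethoxy for fluoro or for methyl, and they disagree on whether that carbon matters: a number 3 percentage points lower from compound 1 to compound 3 (within the scatter) is flat, whereas a number 31 percentage points lower from compound 1 to compound 2 (beyond the scatter) and a number 28 percentage points higher from compound 2 to compound 3 (beyond the scatter) are clear. Shortening ethoxy to methoxy is a smaller change than either exchange, so in this assay a step close to or within the scatter is expected, with some uncertainty downward given the sensitivity that compound 2 reveals.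

Compound 4 is therefore expected to give 78%, between 55% and 95%. The expected step is a number 6 percentage points lower from compound 3 to compound 4 (within the scatter).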

Compound 4, a percentage reported as activity, at one concentration (the size of the read-out at that concentration, not a potency): 78%
The estimate for compound 4 equals the measured number at the digits printed; measured number inside the range.
By their numbers in this assay, from the lowest: compound 2; then compounds 4, 3 and 1 (each within the scatter of the next).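

In this assay, the step within the alkoxy group itself, ethyl to methyl, gives a number 6 percentage points lower from compound 3 to compound 4 (within the scatter), so this saturated chain carbon bound to an oxygen on an aromatic ring shows no readable dependence on chain length across ethoxy and methoxy. The wider comparison on the aromatic carbon also holds with the shorter group: a number 22 percentage points higher from compound 2 to compound 4 (beyond the scatter) keeps the methyl compound apart, whereas a number 9 percentage points lower from compound 1 to compound 4 (within the scatter) leaves methoxy and fluoro unresolved, so among the four compounds only the methyl group in compound 2 separates from the rest. No supporting data bear on why methyl stands apart from fluoro, ethoxy and methoxy at this carbon.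

Open, on these data alone, is whether a longer chain such as propoxy or butoxy would stay level with ethoxy and methoxy, and whether a hydroxyl or an amine on the same aromatic carbon would group with them or with methyl. Also open, as far as these compounds go, is whether an ethyl group or chlorine there would reproduce the separation seen with methyl, and all of these comparisons rest on a single concentration in this assay, which gives no potency.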